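A shorter hydroxycarbamoyl chain on compound 1

The source may report more compounds than this note shows. Statements on the series, on what has been measured and on what is new or still open speak of the compounds shown alone.

The values measured so far in a functional assay on MCF7 cells (Homo sapiens) for inhibition, read by MTT assay, with a stated time of 72 h (a lower number here means a stronger inhibitor, a higher number a weaker inhibitor), are these:
Compound 1 `Nc1nc2cc(-c3nn(CCCC(=O)NO)c4ncnc(N)c34)ccc2o1` gives > 50000 nM (a limit)
Compound 2 `Nc1nc2cc(-c3nn(CCCCCCCCCC(=O)NO)c4ncnc(N)c34)ccc2o1` gives > 50000 nM (a limit)
Compound 3 `Nc1ncnc2c1c(-c1cnc3[nH]ccc3c1)nn2CCCCCCC(=O)NO` gives 19800 nM (a number)

In this assay compound 1 gives > 50000 nM as a limit and not as a number. Compound 2 gives > 50000 nM and that too is only a limit. Compound 1 therefore stands at the limit of > 50000 nM in this assay, at which 2 of the 3 values shown sit, in the data so far. Compound 3 gives 19800 nM and is the only one of the three with a number.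

Compound 4 `Nc1nc2cc(-c3nn(CC(=O)NO)c4ncnc(N)c34)ccc2o1` carries hydroxycarbamoyl in place of 2-(hydroxycarbamoyl)ethyl on a saturated chain carbon bound to an aromatic nitrogen, counted as hydroxycarbamoyl in place of 2-(hydroxycarbamoyl)ethyl on a saturated chain carbon bound to an aromatic nitrogen in this comparison. Going by the values given here, the only measured step along this chain is a step that the two limits leave unreadable from compound 1 to compound 2 and it offers no size to carry over. The expectation thus rests on the limit of > 50000 nM in this assay, at which 2 of the 3 values shown sit, and no gain beyond the scatter is foreseen in this assay for the shorter chain. The expected outcome is a number no higher from compound 1 to compound 4 (the limit leaves the size open) on this reading. The estimate for compound 4 is 50000 nM with an expected range of 15000 nM to 100000 nM and a further limit is quite likely.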

Compound 4, half-maximal inhibitory concentration: > 100000 nM
Compound 4: only a limit was reported; the forecaster's own chance of this, stated with the estimate: 70%; at least 2.0-fold (0.30 log units) between middle value and limit.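

Going by these compounds alone, compound 1 and compound 4 are both reported in this assay only as limits, so no step between them can be read. The compounds shown leave open how the length of the chain carrying hydroxycarbamoyl on the core of compound 1 bears on the read-out, since no compound with that core has a number.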